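Working notes: benzyl in place of tert-butyl, toward compound 4

The compounds below may be only part of what the source reports. "The series", "measured", "known", "first", "only" and "open" are said of these compounds alone.

The three measured compounds share one core and differ only in the group on a carbonyl carbon. Compound 1 `O=C(Nc1ccc2nc(NC(=O)C3CCC3)sc2c1)c1c(Cl)cccc1Cl` gives 0.013 ug/mL in a functional assay on WI-38 VA13 cells (Homo sapiens) for cytotoxicity; on this read-out lower numbers stand for an effect already at smaller amounts and higher numbers for an effect only at larger amounts of compound; compound 2 `CCCC(=O)Nc1nc2ccc(NC(=O)c3c(Cl)cccc3Cl)cc2s1` gives 0.01 ug/mL; compound 3 `CC(C)(C)OC(=O)Nc1nc2ccc(NC(=O)c3c(Cl)cccc3Cl)cc2s1` gives 0.027 ug/mL. Among them compound 3 stands highest: a 2.1-fold higher number from compound 1 to compound 3 (0.32 log units; beyond the scatter) and a 2.7-fold higher number from compound 2 to compound 3 (0.43 log units; beyond the scatter), whereas a 1.3-fold lower number from compound 1 to compound 2 (0.11 log units; within the scatter). Compound 4 `O=C(Nc1nc2ccc(NC(=O)c3c(Cl)cccc3Cl)cc2s1)OCc1ccccc1` differs from compound 3 in one place: benzyl in place of tert-butyl on an oxygen next to a carbonyl group. For the measured compounds named here, no measured step alters a group on this oxygen; the two steps into compound 3 exchange the whole group on the carbonyl carbon, and both were modest and in the same direction, so they hint only that the oxygen-bearing variants sit at the higher end of this small set. The step from compound 3 to compound 4 keeps that oxygen and changes only what sits on it, so the expected outcome is no step beyond the scatter, a 1.1-fold higher number from compound 3 to compound 4 (0.05 log units; within the scatter). For compound 4 the estimate in this assay is 0.03 ug/mL, with a range from 0.012 ug/mL to 0.08 ug/mL.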

Compound 4, half-maximal effective concentration: 0.018 ug/mL
Compound 4: middle estimate off by 1.7-fold (0.22 log units), on the high side; the range from low to high includes it.
By their numbers in this assay, from the lowest: compounds 2, 1, 4 and 3 (each within the scatter of the next, the first and the last beyond it).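

In this assay, for the compounds shown here, this is the first reading of a change on the oxygen next to a carbonyl group, and replacing tert-butyl with benzyl, which brings in a six-membered aromatic ring, stays within the scatter: a 1.5-fold lower number from compound 3 to compound 4 (0.18 log units; within the scatter). The earlier hint that oxygen-bearing variants sit at the higher end of the set therefore rests on tert-butoxy alone, since benzyloxy is not separated from propyl or cyclobutyl on the carbonyl carbon: a 1.8-fold higher number from compound 2 to compound 4 (0.26 log units; within the scatter), and a 1.4-fold higher number from compound 1 to compound 4 (0.14 log units; within the scatter). No available measurement offers an explanation for this result.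

Still open, going by these compounds, is how this assay reads with an amine on the carbonyl carbon or with a longer chain on the oxygen. A carboxylic acid on the benzyl ring is equally unresolved by the compounds shown.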